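The source may hold more compounds than are shown below. What is called first, only, known or untested is meant among the compounds shown, and "the series" means these compounds.

Measured in a functional assay on MDA-MB-231 cells (Homo sapiens) for antiproliferative activity, read by MTT assay, with a stated time of 24 h; a lower number here means a stronger inhibitor, a higher number a weaker inhibitor:
compound 1 `O=C(NNc1ccccc1Cl)c1ccc(NS(=O)(=O)c2cnc(O)nc2O)cc1`: 4010 nM
compound 2 `O=C(NNc1ccccc1Cl)c1cccc(NS(=O)(=O)c2cnc(O)nc2O)c1`: 2090 nM
compound 3 `Cc1ccccc1NNC(=O)c1ccccc1NS(=O)(=O)c1cnc(O)nc1O`: > 20000 nM

The entry for compound 3, > 20000 nM, is a limit and not a number. Among the compounds with values here, compound 1 and compound 2 lie within the usual scatter of each other, so compound 1 stands level with the only other exact value.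

Compound 4 `O=C(NNC(=O)c1cccc(Cl)c1)c1ccc(NS(=O)(=O)c2cnc(O)nc2O)cc1` changes compound 1 as follows: (3-chlorophenyl)carbonyl in place of 2-chlorophenyl on an amine nitrogen. In words, (3-chlorophenyl)carbonyl replaces 2-chlorophenyl on an amine nitrogen. Within the data shown here, no measured pair tests this change, so no step beyond the scatter is expected in this assay. The expected step, a 1.2-fold higher number from compound 1 to compound 4 (0.10 log units; within the scatter), is small and points slightly towards weaker inhibition. For compound 4 the estimated value is 5000 nM, with an expected range of 1500 nM to 17000 nM.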

Compound 4, half-maximal inhibitory concentration: 4160 nM
For compound 4 the middle estimate is 1.2-fold (0.08 log units) above the measured one, and the stated range covers the measured number.
By their numbers in this assay, from the lowest: compounds 2, 1 and 4 (each within the scatter of the next). At a limit, above all of these: compound 3.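

In this assay, (3-chlorophenyl)carbonyl in place of 2-chlorophenyl on an amine nitrogen gives a 1.0-fold higher number from compound 1 to compound 4 (0.02 log units; within the scatter). This amine nitrogen can therefore carry the larger group, with its added carbonyl and hydrogen-bond acceptor, and the value stays within the usual scatter. Nothing measured here accounts for this result.

Going by these compounds, the carbonyl and the altered chlorine arrive together, so their separate contributions remain unknown. Also open, on these data alone, is how a carboxylic acid or an amine on this ring, or a plain alkyl chain in its place, would fare.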